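Piperazine Ring in Place of Methoxy on the Core

The source may hold more compounds than are shown below. What is called first, only, known or untested is meant among the compounds shown, and "the series" means these compounds.

Compounds measured in an assay on HEK293 cells for inhibition of acid ceramidase (Rattus norvegicus), read by LC-MS, with a stated time of 30 min; a higher number here means a weaker inhibitor, a lower number a stronger inhibitor:
compound 1 `CCCCCCNC(=O)n1cc(C)c(=O)[nH]c1=O` gives 1460 nM
compound 2 `CCCCCCNC(=O)n1cc(CC)c(=O)[nH]c1=O` gives 733 nM
compound 3 `CCCCCCNC(=O)n1cc(OC)c(=O)[nH]c1=O` gives 1100 nM

Compound 3 stands second highest of the three numbers; its nearest neighbour is compound 1, with the step of a 1.3-fold lower number from compound 1 to compound 3 (0.12 log units; within the scatter), and its furthest is compound 2, with the step of a 1.5-fold higher number from compound 2 to compound 3 (0.18 log units; within the scatter), both within the scatter. The unmeasured compound 4 `CCCCCCNC(=O)n1cc(N2CCN(C)CC2)c(=O)[nH]c1=O` differs from compound 3 by 4-methylpiperazin-1-yl in place of methoxy on an aromatic carbon. The measured steps that bear on this position are a 2.0-fold lower number from compound 1 to compound 2 (0.30 log units; within the scatter), a 1.3-fold lower number from compound 1 to compound 3 (0.12 log units; within the scatter) and a 1.5-fold higher number from compound 2 to compound 3 (0.18 log units; within the scatter), all within the scatter, so the small groups tried there left this assay nearly unchanged. None of them resembles 4-methylpiperazin-1-yl, so the data give no direct guide for a group with a ring, and the range must stay wide. Compound 4 is expected to give 1500 nM in this assay, with a range from 400 nM to 6000 nM. This amounts to an expected step of a 1.4-fold higher number from compound 3 to compound 4 (0.13 log units; within the scatter), not beyond the scatter.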

Compound 4, half-maximal inhibitory concentration: 1400 nM
Compound 4: the middle estimate sits 1.1-fold (0.03 log units) above what was measured; the measured number falls inside the stated range.
By their numbers in this assay, from the lowest: compounds 2, 3, 4 and 1 (each within the scatter of the next).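

In this assay, the aromatic carbon that had carried only methyl, ethyl and methoxy also takes 4-methylpiperazin-1-yl, a group with one six-membered non-aromatic ring, and the step is a 1.3-fold higher number from compound 3 to compound 4 (0.10 log units; within the scatter). The same holds against the other two groups, with a 1.9-fold higher number from compound 2 to compound 4 (0.28 log units; within the scatter) and a 1.0-fold lower number from compound 1 to compound 4 (0.02 log units; within the scatter). Adding a ring and more heavy atoms at this place therefore leaves compound 4 within the scatter of all three earlier compounds.

The compounds shown leave open whether a primary amine, a carboxylic acid or a longer alkyl chain on this carbon would stay within the same scatter. No measurement here offers an explanation for the flat steps at this position.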